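A few compounds are considered here, and "the series" means these few. Any claim that something is new, unique, unknown or untested is made for them only; others in the source may bear on it.

Working notes on the benzophenone series. Among the compounds with values here, for compound 1 `COc1ccc(C(=O)c2ccc(OC)c(O)c2OC)cc1` the entry in a functional assay on SF-295 cells (Homo sapiens) for cytotoxicity, read by sulforhodamine B assay, with a stated time of 48 h (on this read-out lower numbers stand for stronger inhibition of growth and higher numbers for weaker inhibition of growth), reads "not determined" (no result reported), so compound 2 `COc1ccc(C(=O)c2cc(OC)c(OC)c(OC)c2)c(O)c1O` supplies the only number: in this assay compound 2 gives 120 nM, which is therefore the sole point of reference. Compound 3 `COc1ccc(C(=O)c2cc(OC)c(OC)c(OC)c2)c(OC)c1O` is the next entry to be measured in this assay. It differs from compound 2 by methyl in place of hydrogen on an oxygen on an aromatic ring. Within the data shown here, with one measured value and no measured step for comparison, the expected step of a 2.1-fold higher number from compound 2 to compound 3 (0.32 log units; beyond the scatter) is a small loss, close to the scatter, and compound 3 is estimated at 250 nM within a range of 60 nM to 1200 nM.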

Compound 3, concentration for 50% growth inhibition: 19.9 nM
Estimate against measurement, compound 3: 13-fold (1.10 log units) above, outside the stated range (below it).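

Methyl in place of hydrogen on this oxygen brings a 6.0-fold lower number from compound 2 to compound 3 (0.78 log units; beyond the scatter) in this assay and so turns the hydroxy to methoxy change from an expected small loss into a gain. The hydrogen on this oxygen is therefore not needed for growth inhibition in this pair, and the methyl cap is favoured here. No measurement available here accounts for this gain.

On these data alone, whether a longer chain such as ethoxy, or an amine, would keep the gain at this place remains open. As far as these compounds go, the role of the hydroxy still present in compound 3 is also open.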